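Anilide series: hydroxy in place of sulfo

This account rests on a few compounds, and the source may have more. Where it says the series, first, only, none or still open, it means among the compounds named here.

Measured so far:
compound 1, `C=C(CC)C(=O)c1ccc(OCC(=O)Nc2ccc3c(c2)C(=O)NC3=O)c(Cl)c1Cl` — 2500 nM
compound 2, `C=C(CC)C(=O)c1ccc(OCC(=O)Nc2ccc(S(=O)(=O)O)cc2)c(Cl)c1Cl` — > 25000 nM

In a functional assay on CLL cells (Homo sapiens) for cytotoxicity, read by MTT assay, with a stated time of 48 h (a higher number here means that more compound is needed for the effect, a lower number that less compound is needed), compound 1 gives 2500 nM. Compound 2 is a different case: in this assay compound 2 reports only > 25000 nM, which is a limit of the assay and not a number, so compound 2 stands at the limit of > 25000 nM in this assay, at which 1 of the 2 values shown sits, and the gap to compound 1 can only be read as at least the distance from that limit.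

The next compound is compound 3, `C=C(CC)C(=O)c1ccc(OCC(=O)Nc2ccc(O)cc2)c(Cl)c1Cl`. Compared with compound 2, the change is hydroxy in place of sulfo on an aromatic carbon. Only compound 1 and the limit for compound 2 are in hand, so the size of the step in this assay rests on little; a step downward beyond the scatter is expected, with the estimate kept wide, so that the expected step from compound 2 to compound 3 is an at least 3.1-fold lower number from compound 2 to compound 3 (0.49 log units; beyond the scatter). For compound 3 the expected value in this assay is 8000 nM, within 2500 nM to 25000 nM.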

Compound 3, half-maximal effective concentration: 6400 nM
Beside the measured number, compound 3's estimate is 1.3-fold (0.10 log units) above it; measured number inside the range.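

In this assay, the carbon para to a large group on the anilide ring now has a readable value: hydroxy in place of sulfo gives an at least 3.9-fold lower number from compound 2 to compound 3 (0.59 log units; beyond the scatter). So sulfo is not needed at this position for a measurable effect in this assay, and a group as small as hydroxy is enough to bring the series off the top of the range. Compound 2 gives a limit of the assay and not a number, so the step has a floor but no measured size: the limit of > 25000 nM in this assay, at which 1 of the 3 values shown sits.

A single pair cannot separate the loss of sulfo from the arrival of hydroxy. As far as these compounds go, it also remains open whether an amine, a methoxy group or a carboxylic acid on the same carbon would give a value like that of compound 3.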